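Methoxymethyl removal on the ring oxygen: compound 3 to compound 4

The source may report more compounds than this note shows. Statements on the series, on what has been measured and on what is new or still open speak of the compounds shown alone.

Compound 1 `COc1ccc(C(=O)/C=C/c2ccc(O)c(CC=C(C)C)c2)c(O)c1` is an open-chain relative of the series. In an assay on isolated protein for inhibition of Aromatase (Homo sapiens) (a lower number here means a stronger inhibitor, a higher number a weaker inhibitor), compound 1 gives only a limit, > 295000 nM (the limit of > 295000 nM in this assay, at which 1 of the 3 values shown sits). Compound 2 `COCOc1ccc2c(c1)OC(c1ccc(OCOC)c(CC=C(C)C)c1)CC2=O` carries methoxymethyl on both ring oxygens and in this assay compound 2 gives 14000 nM. Compound 3 `COCOc1ccc2c(c1)OC(c1ccc(OC)c(CC=C(C)C)c1)CC2=O` in this assay gives 7670 nM; compound 3 and compound 2 sit within the scatter of each other. Among the compounds with values here, the only other value in the set belongs to compound 1 and is a limit. Within the data shown here, the step of a 1.8-fold lower number from compound 2 to compound 3 (0.26 log units; within the scatter) is the sole measured change of one group.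

Compound 4 `COc1ccc(C2CC(=O)c3ccc(O)cc3O2)cc1CC=C(C)C` differs from compound 3 by hydrogen in place of methoxymethyl on an oxygen on an aromatic ring. The measured step of a 1.8-fold lower number from compound 2 to compound 3 (0.26 log units; within the scatter) trimmed the same kind of group on the other ring oxygen, on a saturated chain carbon, without moving the number beyond the scatter. Among the measured compounds shown here, only that step bears on the present change; it is not the identical cut. The expectation in this assay is therefore a step near the scatter, a 1.3-fold lower number from compound 3 to compound 4 (0.11 log units; within the scatter), direction uncertain. Compound 4 is estimated at 6000 nM, in the range 2000 nM to 20000 nM.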

Compound 4, half-maximal inhibitory concentration: 4080 nM
Compound 4: the middle estimate sits 1.5-fold (0.17 log units) above what was measured, within the range that was stated.
By their numbers in this assay, from the lowest: compounds 4, 3 and 2 (each within the scatter of the next, the first and the last beyond it). At a limit, above all of these: compound 1.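

In this assay, within the data shown here, the step of a 1.9-fold lower number from compound 3 to compound 4 (0.27 log units; within the scatter) is the first measured change at this ring oxygen, methoxymethoxy to hydroxy. Loss of the methoxymethyl, with its 3 heavy atoms and 1 hydrogen-bond acceptor, therefore leaves the number within the scatter here, as the trim at the other ring oxygen did in the step of a 1.8-fold lower number from compound 2 to compound 3 (0.26 log units; within the scatter). Nothing measured on these compounds accounts for the size of this step.

The compounds shown leave open whether a different kind of group in place of this hydroxy, such as an amine or a longer ether chain, would move the number beyond the scatter. They also leave open what a hydroxy on the other ring oxygen would do with the hydroxy at this position kept.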